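This account rests on a few compounds, and the source may have more. Where it says the series, first, only, none or still open, it means among the compounds named here.

Measured compounds in a functional assay on Bel-7402 cells (Homo sapiens) for cytotoxicity, read by MTT assay; on this read-out lower numbers stand for stronger inhibition and higher numbers for weaker inhibition:
Compound 1 `COc1cc(/C=C/C(=O)c2sc(Nc3ccc(C)cc3)nc2C)cc(OC)c1OC` gives > 25000 nM, which is a limit of the assay and not a number.
Compound 2 `COc1cccc(/C=C/C(=O)c2sc(Nc3cccc(Cl)c3)nc2C)c1` gives > 25000 nM, likewise a limit.
Compound 3 `Cc1ccc(Nc2nc(C)c(C(=O)/C=C/c3ccccc3)s2)cc1` gives > 25000 nM, likewise a limit.

Compound 1 therefore stands where all measured compounds stand: at the limit of > 25000 nM in this assay, at which 3 of the 3 values shown sit. For the measured compounds named here, since every value is a limit, no step between measured compounds can be sized, and no direction of change is visible among them. Compound 4 `COc1cc(/C=C/C(=O)c2sc(Nc3ccccc3)nc2C)cc(OC)c1OC` differs from compound 1 by hydrogen in place of methyl on an aromatic carbon, that is, 4-methylphenyl becomes phenyl. With nothing in the measured set moving off the limit, compound 4 is expected to remain at the limit too, so the step that the limit leaves unreadable from compound 1 to compound 4 is expected to be none beyond the scatter. The estimate for compound 4 is 30000 nM, with a range from 12000 nM to 80000 nM.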

Compound 4, half-maximal inhibitory concentration: > 25000 nM
Compound 4: a limit, no number; the forecaster's own chance of this, stated with the estimate: 85%; the middle value does not contradict the limit.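

For the compounds shown here, compound 1 and compound 4 both give a limit and not a number, so no step between them can be read: the limit of > 25000 nM in this assay, at which 4 of the 4 values shown sit. As far as these compounds go, whether any change to the shared core would give a measurable value stays open.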